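Propyl to ethyl on the amide nitrogen

This account rests on a few compounds, and the source may have more. Where it says the series, first, only, none or still open, it means among the compounds named here.

Measured in a functional assay on K562 cells (Homo sapiens) for antiproliferative activity, read by CCK-8 assay, with a stated time of 72 h; on this read-out lower numbers stand for stronger inhibition of growth and higher numbers for weaker inhibition of growth:
- compound 1 `CCC1C(=O)N(C)c2cnc(-n3ccc4cc(C(=O)NC(C)C)ccc43)nc2N1c1ccn(C)n1` gives 8910 nM
- compound 2 `CCCNC(=O)c1ccc2c(ccn2-c2ncc3c(n2)N(c2ccn(C)n2)C(CC)C(=O)N3C)c1` gives 8270 nM

Compound 2 cannot be separated from compound 1 on these numbers. For the measured compounds named here, the only measured step is a 1.1-fold lower number from compound 1 to compound 2 (0.03 log units; within the scatter), and it concerns propyl in place of isopropyl on the amide-type nitrogen. Compound 3 `CCNC(=O)c1ccc2c(ccn2-c2ncc3c(n2)N(c2ccn(C)n2)C(CC)C(=O)N3C)c1` carries hydrogen in place of methyl on a saturated chain carbon, two bonds along the chain from an amide-type nitrogen, which is hydrogen in place of methyl on a saturated chain carbon, two bonds along the chain from an amide-type nitrogen, or propyl to ethyl. Going by the values given here, that single step is the only guide, and no measured compound has a chain this short. No step beyond the scatter is therefore expected in this assay. The expected change is a 1.0-fold lower number from compound 2 to compound 3 (0.01 log units; within the scatter). The estimate for compound 3 is 8000 nM, with an expected range of 3500 nM to 18000 nM.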

Compound 3, concentration for 50% growth inhibition: 12800 nM
Compound 3: the middle estimate sits 1.6-fold (0.20 log units) below what was measured; low and high end bracket the measured number.
By their numbers in this assay, from the lowest: compounds 2, 1 and 3 (each within the scatter of the next).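

In this assay, going from propyl to ethyl gives a 1.5-fold higher number from compound 2 to compound 3 (0.19 log units; within the scatter), and replacing the isopropyl amide with the ethyl amide gives a 1.4-fold higher number from compound 1 to compound 3 (0.16 log units; within the scatter). With the earlier step, this means the ethyl, propyl and isopropyl amides cannot be told apart on this read-out: shortening the chain by one carbon, like the earlier change from branched to straight chain, produces no step beyond the scatter. No evidence on any property of these compounds bears on this result.

Still open, from the compounds shown here alone, is whether the methyl amide, the unsubstituted amide or a longer chain such as butyl would give a step beyond the scatter at this position. Going by these compounds, it is also open whether an amine or a carboxylic acid at the end of the chain would do so.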